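This account rests on a few compounds, and the source may have more. Where it says the series, first, only, none or still open, it means among the compounds named here.

Working notes on the series. Compound 1 `CC(=O)c1cccc(NC(=O)N[C@H](C)c2ccccc2)c1` and compound 2 `CC(=O)c1ccc(NC(=O)N[C@H](C)c2ccccc2)cc1` are built from the same atoms joined differently; the difference between the two cores is not broken down here. In an ADME assay on the whole organism with Oryza sativa as the target, tested at 1 uM (on this read-out lower numbers stand for a stronger effect and higher numbers for a weaker effect at the one concentration tested), compound 1 gives 88% and compound 2 gives 93%. Compound 3 `C[C@@H](NC(=O)Nc1cccc(F)c1)c1ccccc1` differs from compound 1 by fluoro in place of acetyl on an aromatic carbon; in this assay compound 3 gives 95%, so that a number 7 percentage points higher from compound 1 to compound 3 (within the scatter). Compound 4 `C[C@@H](NC(=O)Nc1ccc(F)cc1)c1ccccc1` is not yet measured and differs from compound 2 by fluoro in place of acetyl on an aromatic carbon. The place is not identical: in compound 3 the fluoro sits meta to a large group, in compound 4 para to a large group, so this is the same kind of change, not the same. A step of similar size is expected from compound 2 to compound 4, namely a number 2 percentage points higher from compound 2 to compound 4 (within the scatter), because a number 7 percentage points higher from compound 1 to compound 3 (within the scatter) stayed within the scatter. Compound 4 is therefore estimated at 95%, roughly between 85% and 100%.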

Compound 4, a percentage reported as activity, at one concentration (the size of the read-out at that concentration, not a potency): 96%
Beside the measured number, compound 4's estimate is 1 percentage points below it; low and high end bracket the measured number.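

In this assay the replacement of acetyl by fluoro gives a number 3 percentage points higher from compound 2 to compound 4 (within the scatter). Set beside the earlier step, the change reads the same on both cores: the same change on two cores in this assay, a number 7 percentage points higher (within the scatter) from compound 1 to compound 3 and a number 3 percentage points higher (within the scatter) from compound 2 to compound 4, 4 percentage points apart, within the scatter of two such steps. This shows only that the change stays within the scatter on the two cores shown; it does not show that acetyl and fluoro are interchangeable in general, that the step would hold on a further core, or that a small real effect is absent, since a step of that size cannot be told from the scatter.

The compounds shown leave open whether an amine, a carboxylic acid or a longer chain on the same aromatic carbon would move the read-out beyond the scatter.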